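Pyrrolopyridine-Triazole Amides: Aryl Substitution and A549 Cytotoxicity

This account rests on a few compounds, and the source may have more. Where it says the series, first, only, none or still open, it means among the compounds named here.

Measured compounds:
- compound 1, `O=C(Nc1ccc(Oc2ccnc3[nH]ccc23)cc1)c1nnn(-c2ccccc2F)c1C(F)(F)F`: 210 nM
- compound 2, `O=C(Nc1ccc(Oc2ccnc3[nH]ccc23)cc1)c1nnn(-c2ccc(F)cc2)c1C(F)(F)F`: 180 nM
- compound 3, `O=C(Nc1ccc(Oc2ccnc3[nH]ccc23)cc1)c1nnn(-c2ccc(F)c(Cl)c2)c1C(F)(F)F`: 1120 nM

All three compounds share one core and differ only in the aryl group attached to an aromatic nitrogen of the triazole. In a functional assay on A549 cells (Homo sapiens) for cytotoxicity, read by MTT assay, with a stated time of 72 h (a higher number here means a weaker inhibitor, a lower number a stronger inhibitor), compound 3 gives 1120 nM, the highest of the three numbers; the nearest is compound 1, and the gap a 5.3-fold higher number from compound 1 to compound 3 (0.73 log units; beyond the scatter) lies beyond the scatter, as does a 6.2-fold higher number from compound 2 to compound 3 (0.79 log units; beyond the scatter).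

Compound 4, `O=C(Nc1ccc(Oc2ccnc3[nH]ccc23)cc1)c1nnn(-c2ccc(Cl)c(C(F)(F)F)c2)c1C(F)(F)F`, has not yet been measured. It differs from compound 3 by 4-chloro-3-(trifluoromethyl)phenyl in place of 3-chloro-4-fluorophenyl on an aromatic nitrogen. Going by the values given here, two measured steps bear on this change. The exchange of a fluorine position, a 1.2-fold lower number from compound 1 to compound 2 (0.07 log units; within the scatter), changed little. The addition of a chlorine to the ring, a 6.2-fold higher number from compound 2 to compound 3 (0.79 log units; beyond the scatter), raised the number clearly. Among the compounds with values here, compound 4 carries a group with more heavy atoms than that of compound 3, so on this evidence a further rise is expected, though its size is uncertain; no measured pair shows a trifluoromethyl on this ring.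

The expectation for compound 4 is 2200 nM, within a range from 600 nM to 8000 nM, which corresponds to an expected step of a 2.0-fold higher number from compound 3 to compound 4 (0.29 log units; within the scatter).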

Compound 4, half-maximal inhibitory concentration: 2340 nM
For compound 4 the middle estimate is 1.1-fold (0.03 log units) below the measured one, and the stated range covers the measured number.
By their numbers in this assay, from the lowest: compounds 2 and 1 (each within the scatter of the next); then compound 3; then compound 4.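

In this assay, the step to the larger aryl group, a 2.1-fold higher number from compound 3 to compound 4 (0.32 log units; beyond the scatter), is modest but lies beyond the scatter, so 4-chloro-3-(trifluoromethyl)phenyl on the aromatic nitrogen gives a weaker result than 3-chloro-4-fluorophenyl. Going by these compounds alone, measured against the two compounds that carry only one fluorine on this ring, the loss is now large: a 13-fold higher number from compound 2 to compound 4 (1.11 log units; beyond the scatter), and an 11-fold higher number from compound 1 to compound 4 (1.05 log units; beyond the scatter). Moving the lone fluorine had changed little, whereas the two compounds with two substituents on the ring both stand clearly higher, and compound 4, with a trifluoromethyl in that pair, stands highest of the four.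

No measurement shown here accounts for these rises. As far as these compounds go, it also stays open how much of the last step belongs to the trifluoromethyl group and how much to the chlorine, since the two rings differ in both substituents at once, and whether a methoxy group, an amine or a carboxylic acid on this ring would keep the number as low as a single fluorine does.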